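A few compounds are considered here, and "the series" means these few. Any claim that something is new, unique, unknown or untested is made for them only; others in the source may bear on it.

Compound 1 `C[C@]1(C(=O)O)CC[C@H](C(=O)N2CC[C@](c3ccc(C(F)(C(F)(F)F)C(F)(F)F)cc3)(S(=O)(=O)c3ccc(F)cc3)C2)CC1` gives 97%
Compound 2 `CCC[C@]1(C(=O)N2CC[C@](c3ccc(C(F)(C(F)(F)F)C(F)(F)F)cc3)(S(=O)(=O)c3ccc(F)cc3)C2)CC[C@H](C(=O)O)CC1` gives "not determined" (no result reported)
Compound 3 `CO[C@]1(C(=O)N2CC[C@](c3ccc(C(F)(C(F)(F)F)C(F)(F)F)cc3)(S(=O)(=O)c3ccc(F)cc3)C2)CC[C@H](C(=O)O)CC1` gives 82%

In an ADME assay on microsomes from liver (Homo sapiens) for metabolic stability, with a stated time of 10 min (a higher number here means that more of the compound is left, a lower number that less of the compound is left), compound 3 holds the lower of the two available numbers (82%), while compound 2 has no number to compare. Compound 4 (`COC[C@]1(C(=O)N2CC[C@](c3ccc(C(F)(C(F)(F)F)C(F)(F)F)cc3)(S(=O)(=O)c3ccc(F)cc3)C2)CC[C@H](C(=O)O)CC1`) has not yet been measured and carries methoxymethyl in place of methoxy on a saturated ring carbon. Among the measured compounds shown here, the only measured step that changes this ring is modest and beyond the scatter (a number 15 percentage points lower from compound 1 to compound 3 (beyond the scatter)). It is a different swap, so it serves only as a loose guide. A small fall that stays within the scatter is therefore expected (a number 7 percentage points lower from compound 3 to compound 4 (within the scatter)). In this assay compound 4 is expected to give 75% with an estimated range of 55% to 92% around it.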

Compound 4, percent of the compound remaining: 100%
Beside the measured number, compound 4's estimate is 25 percentage points below it, outside the stated range (above it).
By their numbers in this assay, from the lowest: compound 3; then compounds 1 and 4 (each within the scatter of the next).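

In this assay, methoxymethyl in place of methoxy on this saturated ring carbon gives a number 18 percentage points higher from compound 3 to compound 4 (beyond the scatter), so one added carbon in the chain can change the result. Replacing 4-carboxy-4-methylcyclohexyl with 4-carboxy-1-(methoxymethyl)cyclohexyl gives a number 3 percentage points higher from compound 1 to compound 4 (within the scatter), so an oxygen in the chain at this place does not by itself bring a lower number. Nothing available explains the difference between methoxy and methoxymethyl. Going by these compounds, whether a longer chain such as methoxyethyl, or an amine on this ring carbon, would give a similar number remains open.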